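The source may hold more compounds than are shown below. What is called first, only, known or untested is meant among the compounds shown, and "the series" means these compounds.

Measured so far:
compound 1 `CCN1CCN(CCC(=O)Nc2nc3c(C)cccc3s2)CC1` 1200 nM
compound 2 `Cc1cccc2sc(NC(=O)CCN3CCN(C(C)C)CC3)nc12` 1800 nM
compound 3 `Cc1cccc2sc(NC(=O)CCN3CCN(CC4CCCCC4)CC3)nc12` 519 nM

All values are from an assay on membranes from liver for displacement of a labelled ligand from Sigma intracellular receptor 2 (Rattus norvegicus), read by scintillation counting, with a stated time of 120 min; a higher number here means a weaker inhibitor, a lower number a stronger inhibitor. Compound 1 stands second highest of the three numbers; its nearest neighbour is compound 2 with a step of a 1.5-fold higher number from compound 1 to compound 2 (0.18 log units; within the scatter), and the furthest is compound 3 with a 2.3-fold lower number from compound 1 to compound 3 (0.36 log units; beyond the scatter). Between compound 2 and compound 3 the step is a 3.5-fold lower number from compound 2 to compound 3 (0.54 log units; beyond the scatter).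

Compound 4 `Cc1cccc2sc(NC(=O)CCN3CCN(c4ccncc4)CC3)nc12` has not been measured. Relative to compound 1 the change is pyridin-4-yl in place of ethyl on an amine nitrogen in a ring. Within the data shown here, the only steps that bear on it are those varying the same ring nitrogen substituent: compound 1 to compound 3 and compound 2 to compound 3, both modest and both toward lower numbers when a larger group enters. No aromatic group at that position has been measured, so the transfer is uncertain. A modest step toward a lower number, or none beyond the scatter, is expected: a 1.5-fold lower number from compound 1 to compound 4 (0.18 log units; within the scatter). Compound 4 is therefore estimated at 800 nM, with a range from 300 nM to 2500 nM.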

Compound 4, inhibition constant: 1700 nM
Estimate against measurement, compound 4: 2.1-fold (0.33 log units) below; the measured number falls inside the stated range.
By their numbers in this assay, from the lowest: compound 3; then compounds 1, 4 and 2 (each within the scatter of the next).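

Pyridin-4-yl, the only aromatic ring among these groups on the amine nitrogen in a ring, stands level with ethyl and isopropyl: a 1.4-fold higher number from compound 1 to compound 4 (0.15 log units; within the scatter), and a 1.1-fold lower number from compound 2 to compound 4 (0.02 log units; within the scatter). Size of the entering group alone therefore does not set the number at this position, since cyclohexylmethyl remains apart: a 3.3-fold higher number from compound 3 to compound 4 (0.52 log units; beyond the scatter). No measurement shown accounts for this difference. Still open, as far as these compounds go, is whether phenyl, lacking the ring nitrogen, or benzyl, carrying a carbon link to the ring, would stand with compound 3 or with compound 4.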